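The compounds below may be only part of what the source reports. "The series", "measured", "known", "first", "only" and "open" are said of these compounds alone.

Measured so far in a functional assay on HepG2 cells (Homo sapiens) for antiproliferative activity, read by CCK-8 assay, with a stated time of 72 h; on this read-out lower numbers stand for stronger inhibition and higher numbers for weaker inhibition:

Compound 1, `O=C(Nc1cccc(-c2oc3cc(-c4ccc(F)cc4)ccc3c(=O)c2O)c1)c1ccc(Cl)cc1`, gives 11000 nM.
Compound 2, `O=C(Nc1cccc(-c2oc3cc(-c4ccc(F)cc4)ccc3c(=O)c2O)c1)c1ccc(C(F)(F)F)cc1`, gives 42700 nM.
Compound 3, `COc1cccc(C(=O)Nc2cccc(-c3oc4cc(-c5ccc(F)cc5)ccc4c(=O)c3O)c2)c1`, gives 9950 nM.

Compound 1 holds the second highest of the three numbers. Its nearest neighbour is compound 3: a 1.1-fold lower number from compound 1 to compound 3 (0.04 log units; within the scatter), within the scatter, so no order between the two can be read. Its furthest is compound 2: a 3.9-fold higher number from compound 1 to compound 2 (0.59 log units; beyond the scatter), a modest step beyond the scatter. The remaining step, a 4.3-fold lower number from compound 2 to compound 3 (0.63 log units; beyond the scatter), is of similar size.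

Compound 4, `O=C(Nc1cccc(-c2oc3cc(-c4ccc(F)cc4)ccc3c(=O)c2O)c1)c1ccc(Cl)nc1`, differs from compound 1 in one place: 6-chloropyridin-3-yl in place of 4-chlorophenyl on a carbonyl carbon. Among the measured compounds shown here, no measured step swaps an aromatic carbon for a hetero atom in this ring; the steps that bear on it are those that replace the whole group on the carbonyl carbon, a 3.9-fold higher number from compound 1 to compound 2 (0.59 log units; beyond the scatter) and a 4.3-fold lower number from compound 2 to compound 3 (0.63 log units; beyond the scatter), both modest, and a 1.1-fold lower number from compound 1 to compound 3 (0.04 log units; within the scatter), within the scatter. The change here is smaller than any of those, so a step within the scatter, or at most a modest one in either direction, is expected in this assay.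

Compound 4 is therefore estimated at 11000 nM, with a range from 4500 nM to 27000 nM. The expected step is no change at the digits printed from compound 1 to compound 4 (within the scatter).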

Compound 4, half-maximal inhibitory concentration: 4610 nM
Beside the measured number, compound 4's estimate is 2.4-fold (0.38 log units) above it; the measured number falls inside the stated range.
By their numbers in this assay, from the lowest: compound 4; then compounds 3 and 1 (each within the scatter of the next); then compound 2.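

In this assay, among the compounds shown here, 6-chloropyridin-3-yl in place of 4-chlorophenyl on the carbonyl carbon gives a 2.4-fold lower number from compound 1 to compound 4 (0.38 log units; beyond the scatter); unlike the earlier steps at this position, this one keeps the chlorine and changes the ring, which now holds a hetero atom and counts one hydrogen-bond acceptor. The same group also gives a 2.2-fold lower number from compound 3 to compound 4 (0.33 log units; beyond the scatter) and a 9.3-fold lower number from compound 2 to compound 4 (0.97 log units; beyond the scatter), so compound 4 has the lowest number of the four, and the last of these steps is the largest yet seen at this position. No measurement at hand bears on why the pyridine ring lowers the number, so the result stands as an observation on these four compounds only.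

Still open, as far as these compounds go, is whether the ring nitrogen carries the step by itself, which an unsubstituted pyridin-3-yl would test against compound 4, or whether it depends on the chlorine, which a 6-methoxypyridin-3-yl or 6-aminopyridin-3-yl would address. A pyrimidine ring on the same carbonyl carbon would show whether a further ring nitrogen moves the number again.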